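Chain shortening that leaves a flat maximal response unchanged

This account rests on a few compounds, and the source may have more. Where it says the series, first, only, none or still open, it means among the compounds named here.

Three compounds built on a shared core were measured for their maximal response. Compound 1 `Cn1cc(-c2ccccc2NCC2=NCCN2)cn1` carries a methyl on the aromatic nitrogen of one core, compound 3 `CCn1cc(-c2ccccc2NCC2=NCCN2)cn1` carries an ethyl in the same position, and compound 2 `CC(C)n1nccc1-c1ccccc1NCC1=NCCN1` carries an isopropyl on a different core. In a functional assay with Alpha-1B adrenergic receptor (Homo sapiens) as the target, read by calcium flux (on this read-out lower numbers stand for smaller maximal responses and higher numbers for larger maximal responses), compound 1 gives 0%. In this assay compound 3 gives 0%, and compound 2 gives 0%. The change from compound 3 to compound 1, (hydrogen in place of methyl on a saturated chain carbon bound to an aromatic nitrogen), produced no change at the digits printed from compound 3 to compound 1 (within the scatter). How the core of compound 2 differs from the core of compound 3 is not broken down here; the two compounds simply show the same maximal response within the usual scatter.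

Compound 4 `CCn1nccc1-c1ccccc1NCC1=NCCN1` is obtained from compound 2 by hydrogen in place of methyl on a saturated chain carbon bound to an aromatic nitrogen and a saturated chain carbon. This is the same kind of change as that from compound 3 to compound 1, but not the same: in compound 4 the saturated chain carbon that loses the methyl is bound to an aromatic nitrogen and a saturated chain carbon, whereas in compound 1 it is bound only to an aromatic nitrogen. Because the step of no change at the digits printed from compound 3 to compound 1 (within the scatter) was flat, and because compound 2 gives 0%, the expected step from compound 2 to compound 4 is no change at the digits printed from compound 2 to compound 4 (within the scatter). Compound 4 is therefore expected to reach about 0% in this assay, with an estimated range from 0% to 8%.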

Compound 4, largest response reached (reported as maximal response), in percent of the reference or control that the assay uses: 0%
The estimate for compound 4 equals the measured number at the digits printed, within the range that was stated.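

Cutting isopropyl to ethyl gave no change at the digits printed from compound 2 to compound 4 (within the scatter) in this assay, so this change on a saturated chain carbon bound to an aromatic nitrogen and a saturated chain carbon left the maximal response flat. Set beside the shortening of ethyl to methyl on the core of compound 3, the change reads the same on both cores: the same change on two cores in this assay, no change at the digits printed (within the scatter) from compound 3 to compound 1 and no change at the digits printed (within the scatter) from compound 2 to compound 4, 0 percentage points apart, within the scatter of two such steps What this shows is limited, since all four compounds share one printed value, with compound 4 at 0%, so the agreement shows only that the change carried from one core to the other without moving a response that was already absent, and it does not show that the change would stay flat on a compound with a measurable maximal response.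

The compounds shown leave open whether any group on the aromatic nitrogen would lift the response in this assay at all, for example a longer chain such as butyl, or a chain ending in an amine or a carboxylic acid. They also leave open whether the two cores would still match once such a group gave a response that could be told apart from that of compound 1.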